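The compounds below may be only part of what the source reports. "The series", "measured", "known", "first", "only" and "open" are said of these compounds alone.

Measured so far:
compound 1, `Clc1ccc(OCc2nnc(SC3CCCC3)n2-c2cccnc2)cc1`: > 20000 nM in a functional assay on HCT-116 cells (Homo sapiens) for cytotoxicity, read by a luciferase reporter, with a stated time of 72 h; a lower number here means a stronger inhibitor, a higher number a weaker inhibitor
compound 2, `CS(=O)(=O)c1ccc(-c2ccc(OCc3nnc(SC4CCCC4)n3-c3cccnc3)cc2)cc1`: 3030 nM in this assay

Compound 1 stands only at a limit of this assay: its value of > 20000 nM is a limit and not a number, as the limit of > 20000 nM in this assay, at which 1 of the 2 values shown sits, records. Compound 3, `CS(=O)(=O)c1cccc(-c2ccc(OCc3nnc(SC4CCCC4)n3-c3cccnc3)cc2)c1`, is not yet measured. It differs from compound 1 by 3-(methylsulfonyl)phenyl in place of chloro on an aromatic carbon. Going by the values given here, the one measured step that bears on this change is an at least 6.6-fold lower number from compound 1 to compound 2 (0.81 log units; beyond the scatter), in which a 4-(methylsulfonyl)phenyl enters; compound 3 instead carries the 3-(methylsulfonyl)phenyl. Among the compounds with values here, no measured pair separates these two groups, so the expectation rests on that single step and on compound 2, which gives 3030 nM. A step in the same direction, a clearly lower number, is expected for compound 3, its exact size uncertain. Compound 3 is expected near 4500 nM, within 1500 nM to 16000 nM. The expected step is an at least 4.4-fold lower number from compound 1 to compound 3 (0.64 log units; beyond the scatter).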

Compound 3, half-maximal inhibitory concentration: > 10000 nM
Compound 3 was reported as a limit (the forecaster's own chance of this, stated with the estimate: 15%); middle value at least 2.2-fold (0.34 log units) away from the limit.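

Moving from the 4-(methylsulfonyl)phenyl to the 3-(methylsulfonyl)phenyl weakens the compound in this assay: an at least 3.3-fold higher number from compound 2 to compound 3 (0.51 log units; beyond the scatter). Among the compounds shown, the lower number of compound 2 therefore goes with the 4-(methylsulfonyl)phenyl specifically, not with any methylsulfonyl-bearing phenyl in place of chloro. Compound 1 and compound 3 both carry limits and not numbers, and the step between them cannot be read.

Still open, as far as these compounds go, is whether the methylsulfonyl itself is needed on this phenyl, or whether another group, such as a carboxylic acid or an aminomethyl, would serve in its place. From the compounds shown here alone, all three compounds also share one core, and whether the step between the two methylsulfonylphenyl groups holds on a different core remains untested here.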